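Aryloxy variation on the thiosemicarbazide series

The compounds below may be only part of what the source reports. "The series", "measured", "known", "first", "only" and "open" are said of these compounds alone.

Among the compounds with values here, compound 2 `O=C(COc1ccc(C(F)(F)F)cc1)NNC(=S)NCc1ccc(-c2ccccc2)cc1` gives 1700 nM in an assay on isolated protein for inhibition of A disintegrin and metalloproteinase with thrombospondin motifs 5 (Homo sapiens), read by spectrophotometry, with stated times of 10 min and 3 h (a lower number here means a stronger inhibitor, a higher number a weaker inhibitor), the higher of two numbers so far; its neighbour compound 1 `O=C(COc1ccc(Cl)cc1)NNC(=S)NCc1ccc(-c2ccccc2)cc1` gives 1200 nM, and the pair differ only within the scatter, a 1.4-fold higher number from compound 1 to compound 2 (0.15 log units; within the scatter). Compound 3 `O=C(COc1ccccc1Cl)NNC(=S)NCc1ccc(-c2ccccc2)cc1` carries 2-chlorophenyl in place of 4-(trifluoromethyl)phenyl on an oxygen on a saturated carbon. Within the data shown here, the one measured step concerned swapping chloro for trifluoromethyl and stayed within the scatter; no measured step speaks to moving the chlorine itself. For compound 3 a step of a 1.3-fold lower number from compound 2 to compound 3 (0.12 log units; within the scatter) is therefore expected, most likely not beyond the scatter. Compound 3 is estimated at 1300 nM, within 500 nM to 3500 nM.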

Compound 3, half-maximal inhibitory concentration: 1900 nM
Compound 3: the middle estimate sits 1.5-fold (0.16 log units) below what was measured, and the stated range covers the measured number.
By their numbers in this assay, from the lowest: compounds 1, 2 and 3 (each within the scatter of the next).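

Moving the chlorine on the aryl group attached through oxygen gives the first measured change of substituent place, and in this assay it stays within the scatter (a 1.6-fold higher number from compound 1 to compound 3 (0.20 log units; within the scatter)). The exchange of 4-(trifluoromethyl)phenyl for 2-chlorophenyl also stays within the scatter (a 1.1-fold higher number from compound 2 to compound 3 (0.05 log units; within the scatter)), so compounds 1, 2 and 3 show no separation across these three aryl groups. No measurement here offers an explanation for this flat response.

Open, on these data alone, is whether a carboxylic acid or an amine on this ring would separate from these values. As far as these compounds go, the effect of a longer chain between the oxygen and the carbonyl also remains open.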